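Swapping Methyl for Difluoromethyl on an Aromatic Oxygen

The source may report more compounds than this note shows. Statements on the series, on what has been measured and on what is new or still open speak of the compounds shown alone.

Of the compounds shown here, three built on one shared core have been measured. Compound 1 `COc1ccc(CNc2cc(C)nc3ccc(OC)cc23)cc1` is the starting point; in a functional assay on MCF-10A cells (Homo sapiens) for antiproliferative activity, with a stated time of 48 h (a higher number here means that more compound is needed for the effect, a lower number that less compound is needed), compound 1 gives 7000 nM. Compound 2 `COc1cccc(CNc2cc(C)nc3ccc(OC)cc23)c1` is made of the same atoms joined differently, and the difference between the two cores is not broken down here. In this assay compound 2 gives 9700 nM, and the values of compound 1 and compound 2 lie within the usual scatter of each other. Compound 3 `COc1ccc2nc(C)cc(NCc3ccc(OC(F)F)cc3)c2c1` differs from compound 1 in one place: difluoromethyl in place of methyl on an oxygen on an aromatic ring. This change gave a 1.5-fold higher number from compound 1 to compound 3 (0.17 log units; within the scatter), so in this assay compound 3 gives 10400 nM.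

Compound 4 `COc1ccc2nc(C)cc(NCc3cccc(OC(F)F)c3)c2c1` has not yet been measured. It stands to compound 2 as compound 3 stands to compound 1: difluoromethyl in place of methyl on an oxygen on an aromatic ring. The place is described in the same words for both pairs, so this is the same change made a second time, now on the core of compound 2. The expected step is a 1.4-fold higher number from compound 2 to compound 4 (0.16 log units; within the scatter), because a 1.5-fold higher number from compound 1 to compound 3 (0.17 log units; within the scatter) stayed within the scatter. With one example only, a different outcome on the core of compound 2 cannot be excluded. Compound 4 is therefore estimated to give 14000 nM in this assay, with a range from 7000 nM to 28000 nM.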

Compound 4, half-maximal effective concentration: 10300 nM
For compound 4 the middle estimate is 1.4-fold (0.13 log units) above the measured one; the measured number falls inside the stated range.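

Made a second time, the swap of methoxy to difluoromethoxy gave a 1.1-fold higher number from compound 2 to compound 4 (0.03 log units; within the scatter) in this assay, a step too small to be told apart from repeat measurements of a single compound. Set side by side, the two results agree, so in this small set the change carried over from one core to the other without a readable effect on the number: the same change on two cores in this assay, a 1.5-fold higher number (0.17 log units; within the scatter) from compound 1 to compound 3 and a 1.1-fold higher number (0.03 log units; within the scatter) from compound 2 to compound 4, 1.4-fold (0.15 log units) apart, within the scatter of two such steps

Among these compounds, this agreement rests on just two pairs in a single assay, and since neither step stands out from the scatter, it shows only that the swap made no clear difference on these two cores, not that it would behave the same way on any other core or in another assay, nor why the number stays where it does.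

Still open, going by these compounds, is whether a trifluoromethyl group or a longer chain on that same oxygen would shift the number beyond the scatter, and what an amine or a carboxylic acid would do in place of the whole methoxy group. The compounds shown also leave untouched the methoxy and methyl groups of the shared core, so the role of those two groups remains unknown.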